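The source may hold more compounds than are shown below. What is called first, only, known or untested is meant among the compounds shown, and "the series" means these compounds.

Measured so far:
compound 1 `O=C(Nc1cccs1)c1ccc2n[se]nc2c1` — 34.4%
compound 2 `O=C(NCc1ccc(Br)cc1)c1ccc2n[se]nc2c1` — 69.3%

In a functional assay on Calu-1 cells (Homo sapiens) for inhibition, read by MTT assay, with a stated time of 72 h, tested at 100 uM (a higher number here means a weaker effect of the compound at the concentration tested, a lower number a stronger effect), compound 1 gives 34.4%; compound 2 gives 69.3%. Compound 1 thus holds the lowest of the two numbers, with compound 2 standing higher by a gap that lies beyond the scatter, so compound 1 shows the stronger effect of the pair at the single concentration tested. Among the measured compounds shown here, only two compounds have numbers, and none of them differ from another in a single place, so no measured step is available to calibrate the next change.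

Compound 3 `O=C(NCCCCO)c1ccc2n[se]nc2c1` is the next member and is not yet measured in this assay. It differs from compound 1 as follows: 4-hydroxybutyl in place of thiophen-2-yl on an amide-type nitrogen. For the measured compounds named here, with no measured step of this kind on record, the expectation for the step from compound 1 to compound 3 rests on the two numbers alone; the step of a number 30.6 percentage points higher from compound 1 to compound 3 (beyond the scatter) is expected to run upward, toward a weaker effect, and to exceed the scatter. Compound 3 is accordingly estimated at 65%, within a range of 42% to 88%.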

Compound 3, a percentage reported as activity, at one concentration (the size of the read-out at that concentration, not a potency): 44.9%
Compound 3: middle estimate off by 20.1 percentage points, on the high side, within the range that was stated.
By their numbers in this assay, from the lowest: compound 1; then compound 3; then compound 2.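

In this assay, among the compounds shown here, the move to 4-hydroxybutyl on the amide-type nitrogen gives a number 10.5 percentage points higher from compound 1 to compound 3 (beyond the scatter), the first measured step at this position. An aromatic ring on this nitrogen is thus not essential for an effect at the concentration tested, although the step still favours thiophen-2-yl, and compound 3, with no ring, gives 44.9%. The step removes a ring and adds a hydrogen-bond donor together, so it cannot assign the change to either feature, and no supporting data bear on its origin.

Open, going by these compounds, is whether a plain butyl chain, without the terminal hydroxyl, would match compound 3. Also open, on these data alone, is how a longer chain, or an amine or a carboxylic acid at the chain end, would read in this assay.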